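The compounds below may be only part of what the source reports. "The series", "measured", "known", "first", "only" and "open" are said of these compounds alone.

Working notes on the series. The compounds share one core; compound 1 is `Oc1cccc(-c2cc(-c3cccnc3)nc(-c3cccc(Cl)c3)c2)c1`, compound 2 is `Oc1cccc(-c2cc(-c3ccc(Cl)cc3)nc(-c3cccnc3)c2)c1`, compound 3 is `Oc1ccc(-c2cc(-c3cccnc3)nc(-c3cccc(Cl)c3)c2)cc1`. In an assay on isolated protein for inhibition of DNA topoisomerase 1 (Homo sapiens), with a stated time of 30 min, tested at 100 uM (a higher number here means a stronger effect of the compound at the concentration tested, a lower number a weaker effect), compound 1 gives 27.6%, compound 2 gives 2.8% and compound 3 gives 55.2%. Compound 1 thus stands second highest of the three numbers; the nearest number is that of compound 2, the furthest that of compound 3. Two single changes from compound 1 have been measured: a number 24.8 percentage points lower from compound 1 to compound 2 (beyond the scatter), and a number 27.6 percentage points higher from compound 1 to compound 3 (beyond the scatter). Both steps are modest and both lie beyond the scatter.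

Compound 4 is `Oc1cccc(-c2cc(-c3ccsc3)nc(-c3cccc(Cl)c3)c2)c1`. It differs from compound 1 by thiophen-3-yl in place of pyridin-3-yl on an aromatic carbon. Neither measured step touches this group: the step to compound 2 moves the chlorine on the 3-chlorophenyl group, the step to compound 3 moves the hydroxyl on the 3-hydroxyphenyl group. Within the data shown here, there is therefore no measured step that bears directly on the change to compound 4, and nothing shows the effect of exchanging the pyridin-3-yl group. With that, the expectation for this assay is a step of no clear direction, most likely none beyond the scatter, so that the estimated step is a number 2.6 percentage points lower from compound 1 to compound 4 (within the scatter). For compound 4 the estimated value in this assay is 25%, within a range from 5% to 50%.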

Compound 4, a percentage reported as inhibition, at one concentration (the size of the read-out at that concentration, not a potency): 26.2%
Compound 4: the middle estimate sits 1.2 percentage points below what was measured; the measured number falls inside the stated range.
By their numbers in this assay, from the lowest: compound 2; then compounds 4 and 1 (each within the scatter of the next); then compound 3.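

In this assay, among these compounds, the step of a number 1.4 percentage points lower from compound 1 to compound 4 (within the scatter) gives the first reading at this position, on an aromatic carbon next to the ring nitrogen: a five-membered aromatic ring with sulfur as its hetero atom stands in for a six-membered aromatic ring with nitrogen as its hetero atom, and the read-out shows no change beyond the scatter. The pyridin-3-yl group is therefore not needed to keep the read-out at this level in this pair, whereas moving the chlorine or the hydroxyl elsewhere on the molecule gave steps beyond the scatter. No supporting data bear on why the exchange leaves the read-out in place.

The compounds shown leave open whether thiophen-3-yl would behave the same way alongside the 4-hydroxyphenyl group of compound 3, the highest number in the series. They also leave open whether this position would accept a group of another kind, such as a plain phenyl, a primary amine, a carboxylic acid or a longer alkyl chain, without a step beyond the scatter.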